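One added methyl on the chain of compound 3

This account rests on a few compounds, and the source may have more. Where it says the series, first, only, none or still open, it means among the compounds named here.

In a functional assay on A549 cells (Homo sapiens) for antiproliferative activity, read by MTT assay, with a stated time of 72 h (on this read-out lower numbers stand for stronger inhibition and higher numbers for weaker inhibition), compound 3 (`CC/C=C/C(=O)Nc1cccc(Oc2nc(Nc3cccc(C#N)c3)nc3c2CSCC3)c1`) gives 10100 nM, the lowest of the three numbers available and beyond the scatter from both others. Compound 2 (`COc1cccc(Nc2nc3c(c(Oc4cccc(NC(=O)/C=C/C(C)C)c4)n2)CSCC3)c1`) gives 25300 nM, and compound 1 (`CC(C)/C=C/C(=O)Nc1cccc(Oc2nc(Nc3ccn(C)n3)nc3c2CSCC3)c1`) gives 33500 nM.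

Compound 4 (`CC(C)/C=C/C(=O)Nc1cccc(Oc2nc(Nc3cccc(C#N)c3)nc3c2CSCC3)c1`) departs from compound 3 in one place: methyl in place of hydrogen on a saturated chain carbon bound to a double-bonded chain carbon and a saturated chain carbon. This turns but-1-en-1-yl into 3-methylbut-1-en-1-yl.

Among the compounds with values here, no measured step makes this change on its own. Within the data shown here, the only step available, a 1.3-fold lower number from compound 1 to compound 2 (0.12 log units; within the scatter), exchanges the group on the nitrogen while both compounds keep the 3-methylbut-1-en-1-yl chain. Compound 2 and compound 3 differ in both the chain and the group on the nitrogen, so their values cannot show how much of the gap belongs to the chain. Still, the two compounds that carry the chain compound 4 will have, compound 1 at 33500 nM and compound 2 at 25300 nM, both stand higher than compound 3. A small rise is therefore expected, possibly no more than the scatter, and the expected step is a 1.5-fold higher number from compound 3 to compound 4 (0.17 log units; within the scatter). The estimated value for compound 4 is 15000 nM, with an expected range from 7500 nM to 30000 nM.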

Compound 4, half-maximal inhibitory concentration: 35900 nM
Compound 4: middle estimate off by 2.4-fold (0.38 log units), on the low side, outside the stated range (above it).
By their numbers in this assay, from the lowest: compound 3; then compounds 2, 1 and 4 (each within the scatter of the next).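

In this assay, within the data shown here, the change from but-1-en-1-yl to 3-methylbut-1-en-1-yl gives a 3.6-fold higher number from compound 3 to compound 4 (0.55 log units; beyond the scatter), the first direct reading of this position: one methyl in place of hydrogen on this saturated chain carbon is enough to move the number beyond the scatter. With the 3-methylbut-1-en-1-yl chain in place, the group on the nitrogen shows no readable effect, since a 1.4-fold higher number from compound 2 to compound 4 (0.15 log units; within the scatter) for cyano in place of methoxy and a 1.1-fold higher number from compound 1 to compound 4 (0.03 log units; within the scatter) for 3-cyanophenyl in place of 1-methyl-1H-pyrazol-3-yl both lie within the scatter, as does the earlier 1.3-fold lower number from compound 1 to compound 2 (0.12 log units; within the scatter). Nothing available explains why this methyl has such an effect on the antiproliferative read-out.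

Going by these compounds, the but-1-en-1-yl chain appears here only with the 3-cyanophenyl group, so it remains open whether the same step would appear with 3-methoxyphenyl or 1-methyl-1H-pyrazol-3-yl on the nitrogen. Also open, on these data alone, is how this position would respond to a longer chain such as pent-1-en-1-yl, or to a dimethylamino group on the chain.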